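Swapping nitro for methoxy on an aromatic carbon

A few compounds are considered here, and "the series" means these few. Any claim that something is new, unique, unknown or untested is made for them only; others in the source may bear on it.

Compound 1 `COc1cc(OC)c2sc(-c3ccc(N/C=C\C(=O)c4cc(OC)c(OC)c(OC)c4)cc3)nc2c1`: 26800 nM
Compound 2 `COc1cc(C(=O)/C=C\Nc2ccc(-c3nc4cc(OC)c(OC)c(OC)c4s3)cc2)cc([N+](=O)[O-])c1OC`: 15800 nM

Of the compounds shown here, two have been measured in a functional assay on MIA PaCa-2 cells (Homo sapiens) for antiproliferative activity, read by sulforhodamine B assay, with a stated time of 48 h; on this read-out lower numbers stand for stronger inhibition and higher numbers for weaker inhibition. Compound 1 gives 26800 nM and compound 2 gives 15800 nM, the lower of the two numbers, with compound 1 as its nearest neighbour at a gap that stays within the scatter of this assay. Both numbers therefore sit in the same weak region, and no order between them can be claimed.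

Compound 3 `COc1cc(C(=O)/C=C\Nc2ccc(-c3nc4cc(OC)c(OC)c(OC)c4s3)cc2)cc(OC)c1OC` has not yet been measured in this assay. It differs from compound 2 in one place: methoxy in place of nitro on an aromatic carbon. Among the measured compounds shown here, no pair of measured compounds here differs by only this kind of exchange, so the data give no step to lean on. With compound 2 at 15800 nM as the only anchor, the step from compound 2 to compound 3 is expected to be a 1.6-fold lower number from compound 2 to compound 3 (0.20 log units; within the scatter), which is not beyond the scatter. Compound 3 is accordingly estimated at 10000 nM, within a range from 3000 nM to 40000 nM.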

Compound 3, half-maximal inhibitory concentration: 29100 nM
The estimate for compound 3 lay 2.9-fold (0.46 log units) below the measured number; measured number inside the range.
By their numbers in this assay, from the lowest: compounds 2, 1 and 3 (each within the scatter of the next).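

In this assay, the aromatic carbon that carries nitro in compound 2 now has a direct reading: methoxy in place of nitro there gives a 1.8-fold higher number from compound 2 to compound 3 (0.27 log units; within the scatter), so this exchange, ortho to a methoxy group, does not separate the two compounds. Among the compounds shown here, a second place is read for the first time at a different aromatic carbon, where methoxy in place of hydrogen gives a 1.1-fold higher number from compound 1 to compound 3 (0.04 log units; within the scatter), and this exchange does not separate its two compounds either. With both steps within the scatter, neither exchange has moved the number by an amount that can be read, and nothing available bears on the reason.

As far as these compounds go, whether an amine or a carboxylic acid on the aromatic carbon held by nitro and methoxy would bring the number out of this weak region stays open. The compounds shown also leave open whether hydrogen or a longer chain such as ethoxy at that carbon, or any group other than hydrogen and methoxy at the second place, would read differently.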